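Swapping naphthalen-1-yl for 4-chlorophenyl: little change expected

The compounds below may be only part of what the source reports. "The series", "measured", "known", "first", "only" and "open" are said of these compounds alone.

In a functional assay on SW-620 cells (Homo sapiens) for inhibition, read by sulforhodamine B assay, with a stated time of 48 h, tested at 10 uM (on this read-out lower numbers stand for less inhibition and higher numbers for more inhibition at the one concentration tested (going by the name of the read-out)), compound 2 `c1ccc2c(-c3cn4ccnc4c(-c4ccc5ncn(C6CCCCC6)c5c4)n3)cccc2c1` gives 5.34%, the lowest of the two numbers measured, while its nearest neighbour compound 1 `c1ccc(-c2cn3ccnc3c(-c3ccc4ncn(C5CCCCC5)c4c3)n2)cc1` gives 9.15%; the step of a number 3.8 percentage points lower from compound 1 to compound 2 (within the scatter) stays within the scatter. Compound 3 `Clc1ccc(-c2cn3ccnc3c(-c3ccc4ncn(C5CCCCC5)c4c3)n2)cc1` differs from compound 2 by 4-chlorophenyl in place of naphthalen-1-yl on an aromatic carbon. Among the compounds with values here, the only measured step that bears on this change, the one replacing phenyl by naphthalen-1-yl, was within the scatter, so no step beyond the scatter is expected in this assay. Compound 3 is therefore estimated to give 8%, between 0% and 20%, an expected step of a number 2.7 percentage points higher from compound 2 to compound 3 (within the scatter).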

Compound 3, a percentage reported as inhibition, at one concentration (the size of the read-out at that concentration, not a potency): 14%
Compound 3: middle estimate off by 6 percentage points, on the low side; low and high end bracket the measured number.
By their numbers in this assay, from the lowest: compounds 2, 1 and 3 (each within the scatter of the next).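

In this assay, this position now carries three aryl groups, and every step among them stays within the scatter: 4-chlorophenyl in place of naphthalen-1-yl gives a number 8.7 percentage points higher from compound 2 to compound 3 (within the scatter), and chloro in place of hydrogen on an aromatic carbon gives a number 4.9 percentage points higher from compound 1 to compound 3 (within the scatter). Neither change separates these compounds on this read-out. No measurement at hand offers an explanation for these numbers. The compounds shown leave open whether an amine, a carboxylic acid or a methoxy group at this position would give a step beyond the scatter.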